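This account rests on a few compounds, and the source may have more. Where it says the series, first, only, none or still open, it means among the compounds named here.

Compound 1 `CCOC(=O)c1ccc(-c2nn(Cc3cccc(Cl)c3)c3ccccc23)cc1`: 80 nM
Compound 2 `CCOC(=O)c1ccc(-c2nn(Cc3ccccn3)c3ccccc23)cc1`: 290 nM

In a functional assay on cells (Platelet, Homo sapiens) for inhibition (a higher number here means a weaker inhibitor, a lower number a stronger inhibitor), compound 2 gives 290 nM, the higher of the two numbers, which makes it the weaker inhibitor of the pair. Compound 3 `CCOC(=O)c1ccc(-c2nn(Cc3ccncc3)c3ccccc23)cc1` has the same atoms, joined differently: pyridin-4-yl in place of pyridin-2-yl on a saturated chain carbon bound to an aromatic nitrogen. Here pyridin-4-yl stands in place of pyridin-2-yl on a saturated chain carbon bound to an aromatic nitrogen. Going by the values given here, the only measured step at this place is a 3.6-fold higher number from compound 1 to compound 2 (0.56 log units; beyond the scatter), a modest one that brought in pyridin-2-yl for 3-chlorophenyl. Among the compounds with values here, no two pyridine compounds have yet been compared, so the direction is open and only a small change is expected. The expected step is a 1.1-fold higher number from compound 2 to compound 3 (0.06 log units; within the scatter), an estimate. For compound 3 the estimated value is 330 nM, with an expected range of 120 nM to 900 nM.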

Compound 3, half-maximal inhibitory concentration: 5630 nM
Beside the measured number, compound 3's estimate is 17-fold (1.23 log units) below it; measured number above the stated range.
By their numbers in this assay, from the lowest: compound 1; then compound 2; then compound 3.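

In this assay, changing pyridin-2-yl to pyridin-4-yl gives a 19-fold higher number from compound 2 to compound 3 (1.29 log units; beyond the scatter) even though both groups have the same atoms and the same counts of donors and acceptors. At this place, then, how the ring atoms are arranged matters as well as which atoms are present, and replacing 3-chlorophenyl with pyridin-4-yl gives a 70-fold higher number from compound 1 to compound 3 (1.85 log units; beyond the scatter). Nothing available explains why these two pyridine groups differ so much. Still open, as far as these compounds go, is where pyridin-3-yl would fall, and how an unsubstituted phenyl or a longer chain at this place would behave.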